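Heteroaryl swaps on a shared core: notes toward compound 4

The source may hold more compounds than are shown below. What is called first, only, known or untested is meant among the compounds shown, and "the series" means these compounds.

compound 1, `COc1ccc(OC)c(C(=O)/C=C/c2ccoc2)c1` — 22100 nM
compound 2, `COc1ccc(OC)c(C(=O)/C=C/c2cccs2)c1` — 11000 nM
compound 3, `COc1ccc(OC)c(C(=O)/C=C/c2sccc2C)c1` — 22200 nM

Three measured compounds share one core and differ only in the five-membered aromatic ring on a double-bonded chain carbon bound to a double-bonded chain carbon. In a functional assay on A549 cells (Homo sapiens) for cytotoxicity, read by MTT assay (a higher number here means a weaker inhibitor, a lower number a stronger inhibitor), compound 2 gives the lowest of the three numbers, but neither neighbour separates from it: a 2.0-fold lower number from compound 1 to compound 2 (0.30 log units; within the scatter) and a 2.0-fold higher number from compound 2 to compound 3 (0.30 log units; within the scatter) both stay inside the usual spread, as does a 1.0-fold higher number from compound 1 to compound 3 (0.00 log units; within the scatter). Going by the values given here, on these numbers no compound can be called more or less potent than another.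

Compound 4, `COc1ccc(OC)c(C(=O)/C=C/c2occc2Br)c1`, is not yet measured. 3-bromofuran-2-yl in place of thiophen-2-yl on a double-bonded chain carbon bound to a double-bonded chain carbon

Two kinds of measured step bear on this change: exchanging one five-membered aromatic ring for another, seen from compound 1 to compound 2 and from compound 1 to compound 3, and placing a substituent on an aromatic carbon of that ring, seen from compound 2 to compound 3. None of these moved the number beyond the scatter, and compound 4 combines both kinds of change. The expectation is therefore a step of a 1.5-fold higher number from compound 2 to compound 4 (0.16 log units; within the scatter) in this assay, nothing the repeated measurement would resolve. Compound 4 is expected to give about 16000 nM, with a range from 7000 nM to 36000 nM.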

Compound 4, half-maximal inhibitory concentration: 14900 nM
For compound 4 the middle estimate is 1.1-fold (0.03 log units) above the measured one; the range from low to high includes it.
By their numbers in this assay, from the lowest: compounds 2, 4, 1 and 3 (each within the scatter of the next).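

In this assay, a bromine-bearing furan on a double-bonded chain carbon bound to a double-bonded chain carbon still leaves the series unresolved: a 1.4-fold higher number from compound 2 to compound 4 (0.13 log units; within the scatter), a 1.5-fold lower number from compound 3 to compound 4 (0.17 log units; within the scatter) and a 1.5-fold lower number from compound 1 to compound 4 (0.17 log units; within the scatter). The earlier compounds shown here covered only furan-3-yl, thiophen-2-yl and 3-methylthiophen-2-yl, so the new result extends the set of rings at this position that stay within the scatter of one another to 3-bromofuran-2-yl, and all four compounds now form a single group with no ordering that the assay can resolve. No measurement bears on why this change leaves the number within the scatter.

Compound 4 differs from compound 2 in both the ring and the bromine, so the compounds shown do not separate the contribution of each. All four groups at this position are uncharged five-membered aromatic rings with one hetero atom, which leaves open whether an amine, a carboxylic acid or a longer chain in their place would move the number in this assay beyond the scatter.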